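A few compounds are considered here, and "the series" means these few. Any claim that something is new, unique, unknown or untested is made for them only; others in the source may bear on it.

Measured compounds:
- compound 1, `C[Se]/C(=N\C(=O)c1ccco1)NC(=O)c1ccco1`, 0.05 nM
- compound 2, `O=C(/N=C(/NC(=O)c1cccs1)[Se]Cc1ccccc1)c1cccs1`, 55100 nM
- compound 3, `CS/C(=N\C(=O)c1cccs1)NC(=O)c1cccs1`, 77900 nM

Three compounds share one core, in which a carbon flanked by two amide groups also carries a selenium or sulfur. In a functional assay on HT-29 cells (Homo sapiens) for cytotoxicity, read by MTT assay, with a stated time of 72 h (a lower number here means a stronger inhibitor of growth, a higher number a weaker inhibitor of growth), compound 1 gives 0.05 nM, the lowest of the three numbers, and the gap to compound 2 with 55100 nM and to compound 3 with 77900 nM lies far beyond the scatter.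

Compound 4, `O=C(/N=C(/NC(=O)c1ccco1)[Se]Cc1ccccc1)c1ccco1`, differs from compound 1 in one place: phenyl in place of hydrogen on a saturated chain carbon bound to a selenium atom. For the measured compounds named here, only one measured step touches this region of the molecule: a 1.4-fold higher number from compound 2 to compound 3 (0.15 log units; within the scatter). That step changes selenium to sulfur as well as benzyl to methyl, so it does not isolate the change in question, and it sits in a pair of compounds with thiophene rather than furan amides. Compound 1 stands so far apart from compound 2 and compound 3 that its number carries little of a pattern to lean on. For compound 4 the expected outcome is 50 nM, within 0.05 nM to 50000 nM, which means an expected step of a 1000-fold higher number from compound 1 to compound 4 (3.00 log units; beyond the scatter), a weakening beyond the scatter.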

Compound 4, concentration for 50% growth inhibition: 7190 nM
Compound 4: the middle estimate sits 140-fold (2.16 log units) below what was measured; the measured number falls inside the stated range.
By their numbers in this assay, from the lowest: compound 1; then compound 4; then compounds 2 and 3 (each within the scatter of the next).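

Phenyl in place of hydrogen on a saturated chain carbon bound to a selenium atom gives a 140000-fold higher number from compound 1 to compound 4 (5.16 log units; beyond the scatter) in this assay, so this one change, with the rest of compound 1 untouched, accounts for a very large shift. The earlier step, a 1.4-fold higher number from compound 2 to compound 3 (0.15 log units; within the scatter), swapped benzyl for methyl and selenium for sulfur together, and it gave no sign that this position could matter so much in compound 1. Nothing at hand explains the size of this new step.

As far as these compounds go, an ethyl group or a longer chain in place of the methyl of compound 1, or a carboxylic acid on that chain, lies outside the set, so how the number moves as this group grows stays open. Also open is what selenium contributes, as no pair shown differs in that atom alone.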